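Fluoro for trifluoromethyl on a fused aromatic ring

The compounds below may be only part of what the source reports. "The series", "measured", "known", "first", "only" and "open" are said of these compounds alone.

Compound 1 `CCC(c1nc2ncc(Cl)cc2[nH]1)[C@H]1CC[C@@H](c2ccnc3ccc(C(F)(F)F)cc32)CC1` gives the lowest number of the three measured compounds in an assay on tissue (M109 cells) for inhibition of Indoleamine 2,3-dioxygenase 1 (Mus musculus), read by fluorescence, with a stated time of 18 h (on this read-out higher numbers stand for weaker inhibition and lower numbers for stronger inhibition), at 3 nM. Compound 2 `C[C@@H](c1nc2ncc(Cl)cc2[nH]1)[C@H]1CC[C@@H](c2ccnc3ccc(F)cc32)CC1` gives 36 nM in this assay, a value beyond the scatter above compound 1, and compound 3 `CCOCC(Nc1nnc(-c2ccc(OC)cc2)o1)[C@H]1CC[C@@H](c2ccnc3ccc(C(F)(F)F)cc32)CC1` gives 57 nM, also beyond the scatter above compound 1.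

Compound 4 `CCC(c1nc2ncc(Cl)cc2[nH]1)[C@H]1CC[C@@H](c2ccnc3ccc(F)cc32)CC1` is not yet measured. It differs from compound 1 in one place: fluoro in place of trifluoromethyl on an aromatic carbon. Among the measured compounds shown here, no measured pair shows this exchange alone. Compound 2 carries fluoro at this position but differs from compound 1 elsewhere as well. The value of compound 2, 36 nM, can therefore only hint at the direction. Against that background, a moderate loss of potency is expected for compound 4, with the step of a 3.3-fold higher number from compound 1 to compound 4 (0.52 log units; beyond the scatter) judged likely to lie beyond the scatter. That expected step is judged smaller than the gap between compound 1 and compound 2. Compound 4 is therefore estimated at 10 nM in this assay, within a range of 3 nM to 35 nM.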

Compound 4, half-maximal inhibitory concentration: 5 nM
For compound 4 the middle estimate is 2.0-fold (0.30 log units) above the measured one; the measured number falls inside the stated range.
By their numbers in this assay, from the lowest: compounds 1 and 4 (each within the scatter of the next); then compounds 2 and 3 (each within the scatter of the next).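

The exchange of trifluoromethyl for fluoro on this aromatic carbon can now be read on its own, and in this assay it gives a 1.7-fold higher number from compound 1 to compound 4 (0.22 log units; within the scatter). With the rest of compound 1 unchanged, the two groups cannot be told apart on this read-out, so trifluoromethyl is not required at this position to keep the number within the scatter of compound 1. This rests on a single pair and a single assay. Nothing measured here bears on why the two groups read alike.

The compounds shown leave open whether a nitrile, a methoxy group or an amine on this carbon would also stay within the scatter. They also leave open whether the same exchange would read alike on the remainder of compound 3.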